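A few compounds are considered here, and "the series" means these few. Any claim that something is new, unique, unknown or untested is made for them only; others in the source may bear on it.

Compound 1 `O=C(Nc1ccc(Oc2ccnc3[nH]ccc23)cc1)c1cn(-c2ccc(Br)cc2)c2ccccc2c1=O` gives 450 nM in a functional assay on A549 cells (Homo sapiens) for inhibition, read by MTT assay, with a stated time of 72 h; on this read-out higher numbers stand for weaker inhibition and lower numbers for stronger inhibition. Compound 2 `Cn1ccc2c(Oc3ccc(NC(=O)c4cn(-c5ccccc5)c5ccccc5c4=O)cc3F)ccnc21` gives 1720 nM in this assay, and compound 3 `Cn1ccc2c(Oc3ccc(NC(=O)c4cn(-c5ccc(F)cc5)c5ccccc5c4=O)cc3F)ccnc21` gives 1460 nM in this assay. Among these three numbers compound 3 holds the second highest; compound 2 lies nearest, within the scatter, and compound 1 furthest, beyond it. For the measured compounds named here, the one single-point step measured so far, a 1.2-fold lower number from compound 2 to compound 3 (0.07 log units; within the scatter), is fluoro in place of hydrogen on an aromatic carbon and stays within the scatter. Compound 4 `Cn1ccc2c(Oc3ccc(NC(=O)c4cn(-c5ccc(Cl)cc5)c5ccccc5c4=O)cc3F)ccnc21` has not yet been measured. It differs from compound 3 by chloro in place of fluoro on an aromatic carbon. Going by the values given here, no measured step trades fluoro for chloro; compound 1 carries bromo at that site but also differs from compound 3 in two other places, so its number is not a clean guide. Among the compounds with values here, with the only related step within the scatter, the step of a 1.2-fold lower number from compound 3 to compound 4 (0.09 log units; within the scatter) is expected to stay within the scatter as well. Compound 4 is therefore estimated at 1200 nM in this assay, with a range from 500 nM to 3000 nM.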

Compound 4, half-maximal inhibitory concentration: 250 nM
Compound 4: middle estimate off by 4.8-fold (0.68 log units), on the high side; measured number below the stated range.
By their numbers in this assay, from the lowest: compounds 4 and 1 (each within the scatter of the next); then compounds 3 and 2 (each within the scatter of the next).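

At this position, on a six-membered aromatic ring of carbon only and para to a large group, the identity of the halogen matters in this assay. Chloro in place of fluoro gives a 5.8-fold lower number from compound 3 to compound 4 (0.77 log units; beyond the scatter) and chloro in place of hydrogen gives a 6.9-fold lower number from compound 2 to compound 4 (0.84 log units; beyond the scatter) and both lie beyond the scatter, whereas fluoro in place of hydrogen gave a 1.2-fold lower number from compound 2 to compound 3 (0.07 log units; within the scatter) and stayed within it. Nothing at hand accounts for this separation between the 4-chlorophenyl and 4-fluorophenyl compounds.

Going by these compounds, how a methoxy group or an amine at this site would read remains open. On these data alone, compound 1 carries bromo here but differs from compound 4 in more than one place, so the effect of bromo in place of chloro also remains open.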